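From cyclopentyl to pentyl: a small expected step

The source may hold more compounds than are shown below. What is called first, only, known or untested is meant among the compounds shown, and "the series" means these compounds.

Compound 1 `O=S(=O)(/C=C/c1ccc(O)c(O)c1)CCC1CCCCC1` gives 9800 nM
Compound 2 `O=S(=O)(/C=C/c1ccc(O)c(O)c1)CC1CCCCO1` gives 10800 nM
Compound 3 `O=S(=O)(/C=C/c1ccc(O)c(O)c1)CCC1CCCC1` gives 6800 nM

In a functional assay, read by fluorescence and spectrophotometry, with a stated time of 1 h (on this read-out higher numbers stand for an effect only at larger amounts of compound and lower numbers for an effect already at smaller amounts), compound 3 gives 6800 nM and stands within the scatter of the other two values. Compound 4 `CCCCCCCS(=O)(=O)/C=C/c1ccc(O)c(O)c1` is still unmeasured. Its difference from compound 3 is pentyl in place of cyclopentyl on a saturated chain carbon, two bonds along the chain from a sulfonyl sulfur with the ring opened to a chain of the same size. Within the data shown here, no measured step makes that exact change. The closest guides swap groups at the same end of the molecule: a 1.4-fold lower number from compound 1 to compound 3 (0.16 log units; within the scatter) and a 1.6-fold lower number from compound 2 to compound 3 (0.20 log units; within the scatter) and a 1.1-fold higher number from compound 1 to compound 2 (0.04 log units; within the scatter) all stay within the scatter. No step beyond the scatter is therefore expected in this assay and the expected change is a 1.2-fold higher number from compound 3 to compound 4 (0.07 log units; within the scatter) for now. Compound 4 is estimated at 8000 nM with an expected range from 4000 nM to 16000 nM until it is measured.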

Compound 4, half-maximal effective concentration: 7100 nM
Estimate against measurement, compound 4: 1.1-fold (0.05 log units) above; the range from low to high includes it.
By their numbers in this assay, from the lowest: compounds 3, 4, 1 and 2 (each within the scatter of the next).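

In this assay, opening the cyclopentyl ring to a pentyl chain, on a saturated chain carbon, two bonds along the chain from a sulfonyl sulfur, gives a 1.0-fold higher number from compound 3 to compound 4 (0.02 log units; within the scatter) and so leaves the number within the scatter. An open chain therefore does as well here as a ring: a 1.4-fold lower number from compound 1 to compound 4 (0.14 log units; within the scatter) and a 1.5-fold lower number from compound 2 to compound 4 (0.18 log units; within the scatter) also stay within the scatter. No supporting data offer an explanation for this flat result. The compounds shown leave open whether an amine or a carboxylic acid at this place would move the number, and whether a longer chain such as decyl would.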